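Catechol vinyl sulfone series: shortening the sulfonyl alkyl chain

A few compounds are considered here, and "the series" means these few. Any claim that something is new, unique, unknown or untested is made for them only; others in the source may bear on it.

Measured compounds:
compound 1 `CCCCCCCCCCCCS(=O)(=O)/C=C/c1ccc(O)c(O)c1` — 8500 nM
compound 2 `O=S(=O)(/C=C/c1ccc(O)c(O)c1)CC1CCCCC1` — 7500 nM
compound 3 `O=S(=O)(/C=C/c1ccc(O)c(O)c1)CCCCCCCO` — 5900 nM

All three numbers come from a functional assay, read by fluorescence and spectrophotometry, with a stated time of 1 h; a lower number here means that less compound is needed, a higher number that more compound is needed for the effect. Compound 1 gives the highest number of the three, but its gaps to the others are small: a 1.4-fold lower number from compound 1 to compound 3 (0.16 log units; within the scatter), and the difference between compound 1 and compound 2 is smaller still and within the scatter. Going by the values given here, the series so far reads as flat.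

Compound 4 `CCCCCCCS(=O)(=O)/C=C/c1ccc(O)c(O)c1` is not yet measured. Relative to compound 1 the change is hydrogen in place of pentyl on a saturated chain carbon, seven bonds along the chain from a sulfonyl sulfur.

The step that bears most directly on this is the one at the same chain position, where the pentyl was exchanged for hydroxy: a 1.4-fold lower number from compound 1 to compound 3 (0.16 log units; within the scatter), within the scatter. The step at the sulfur-bound carbon, a 1.3-fold lower number from compound 2 to compound 3 (0.10 log units; within the scatter), is also within the scatter. Neither exchange of the outer part of the chain moved this assay appreciably, so for compound 4 no step beyond the scatter is expected in either direction; the estimate is a 1.1-fold lower number from compound 1 to compound 4 (0.03 log units; within the scatter). Compound 4 is expected to give about 8000 nM, with a range of 4000 nM to 16000 nM.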

Compound 4, half-maximal effective concentration: 7100 nM
Compound 4: middle estimate off by 1.1-fold (0.05 log units), on the high side, and the stated range covers the measured number.
By their numbers in this assay, from the lowest: compounds 3, 4, 2 and 1 (each within the scatter of the next).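

Taking off the pentyl at this chain position and leaving hydrogen there gives (a 1.2-fold lower number from compound 1 to compound 4 (0.08 log units; within the scatter)) in this assay, so the outer part of the chain can be removed outright without a step beyond the scatter; earlier, only its exchange for hydroxy had been seen. The hydroxy on the heptyl chain also carries no step beyond the scatter (a 1.2-fold higher number from compound 3 to compound 4 (0.08 log units; within the scatter)), and the same holds at the sulfur-bound carbon for hexyl in place of cyclohexyl (a 1.1-fold lower number from compound 2 to compound 4 (0.02 log units; within the scatter)). No measurement here bears on why these steps stay so small.

Still open, on these data alone, is whether any group at this chain position can move this assay beyond the scatter, for example an amine or a carboxylic acid in place of the pentyl. Also open, as far as these compounds go, is whether a much shorter chain on the sulfonyl sulfur, such as methyl, would do so.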